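The source may report more compounds than this note shows. Statements on the series, on what has been measured and on what is new or still open speak of the compounds shown alone.

In an ADME assay (liver, Mus musculus) for metabolic stability, using microsomes (on this read-out higher numbers stand for a longer-lived compound and lower numbers for a shorter-lived compound), compound 1 `CCc1nc2cc(Cl)ccn2c1C(=O)NCc1ccc(-c2ccc(C(=O)O)cc2)cc1` gives > 2 h, which is a limit of the assay and not a number. Compound 2 `CCc1nc2cc(Cl)ccn2c1C(=O)NCc1ccc(N2CCC(Cl)CC2)cc1` gives 0.0867 h and compound 3 `CCc1nc2cc(Cl)ccn2c1C(=O)NCc1ccc(N2CCN(C(C)C)CC2)cc1` gives 0.148 h, two values within the scatter of each other. Replacing 4-carboxyphenyl gave large steps: an at least 23-fold lower number from compound 1 to compound 2 (1.36 log units; beyond the scatter) and an at least 13-fold lower number from compound 1 to compound 3 (1.13 log units; beyond the scatter). Compound 4 `CCc1nc2cc(Cl)ccn2c1C(=O)NCc1ccc(N2CC3CCCCC3C2)cc1` differs from compound 3 by a group of 9 heavy atoms (8 carbon, 1 nitrogen; one five-membered non-aromatic ring with 1 hetero atom, one six-membered non-aromatic ring of carbon only) in place of a group of 9 heavy atoms (7 carbon, 2 nitrogen; one six-membered non-aromatic ring with 2 hetero atoms), on an aromatic carbon. No 4-carboxyphenyl group is involved in this change, so those large steps offer little guidance. The closer guide is a 1.7-fold higher number from compound 2 to compound 3 (0.23 log units; within the scatter), which stays within the scatter. No change beyond the scatter is therefore expected in this assay, and the expected step is a 1.5-fold lower number from compound 3 to compound 4 (0.17 log units; within the scatter). The estimated half-life of compound 4 is 0.1 h, with an expected range of 0.04 h to 0.25 h.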

Compound 4, half-life: 0.105 h
Estimate against measurement, compound 4: 1.1-fold (0.02 log units) below; measured number inside the range.
By their numbers in this assay, from the lowest: compounds 2, 4 and 3 (each within the scatter of the next). At a limit, above all of these: compound 1.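

In this assay, on an aromatic carbon para to a large group, the entering group with one five-membered and one six-membered non-aromatic ring, which has no second ring nitrogen, behaves like both amines it is compared with: a 1.4-fold lower number from compound 3 to compound 4 (0.15 log units; within the scatter), and a 1.2-fold higher number from compound 2 to compound 4 (0.08 log units; within the scatter). The step from the carboxyphenyl compound is of another size: an at least 19-fold lower number from compound 1 to compound 4 (1.27 log units; beyond the scatter). Compound 1 gives a limit of the assay and not a number: the limit of > 2 h in this assay, at which 1 of the 4 values shown sits.

Open, as far as these compounds go, is whether a morpholine at this place would leave the half-life within the same scatter. Also open, from the compounds shown here alone, is whether a carboxylic acid without its phenyl ring would bring a non-aromatic group closer to compound 1.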